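A few compounds are considered here, and "the series" means these few. Any claim that something is new, unique, unknown or untested is made for them only; others in the source may bear on it.

Compound 1 `COc1ccccc1C(=O)NC(=O)Nc1ccc(-c2nccs2)c(C(F)(F)F)c1` was measured in a physicochemical assay for solubility, in phosphate buffer, at pH 7.4 (a higher number here means a more soluble compound, a lower number a less soluble compound), and gave only a limit of the assay, < 1 ug/mL. Among the compounds with values here, its single measured neighbour, compound 2 `COc1ccccc1C(=O)NC(=O)Nc1ccc(OCC(F)(F)F)c(C(F)(F)F)c1`, likewise gave only a limit in this assay, < 1 ug/mL. The step that the two limits leave unreadable from compound 1 to compound 2 therefore cannot be read in size or direction, and all that the two numbers share is the limit of < 1 ug/mL in this assay, at which 2 of the 2 values shown sit. Compound 3 `COc1ccccc1C(=O)NC(=O)Nc1ccc(C(C)C)c(C(F)(F)F)c1` has not yet been measured in this assay; it differs from compound 1 in one place, (isopropyl in place of 1,3-thiazol-2-yl on an aromatic carbon). Within the data shown here, no measured step makes this particular change, and the one measured step away from compound 1 is unreadable, so nothing in the numbers points up or down; the only guide is that both measured values sit at the same limit. For compound 3 the expected step is a number no lower from compound 1 to compound 3 (the limit leaves the size open). The estimated solubility of compound 3 in this assay is 1 ug/mL, with a range from 0.3 ug/mL to 4 ug/mL, and a fair chance that the assay again reports only a limit rather than a number.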

Compound 3, solubility: < 1 ug/mL
Compound 3 gave a limit, no number; the forecaster's own chance of this, stated with the estimate: 60%; the middle value lies on the limit itself.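

Compound 3 gives only a limit of the assay, as do compound 1 and compound 2, so no step among these three compounds can be read in this assay: the limit of < 1 ug/mL in this assay, at which 3 of the 3 values shown sit. On these data alone, whether compound 1, compound 2 and compound 3 truly differ in solubility, and in what order, remains open.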